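This account rests on a few compounds, and the source may have more. Where it says the series, first, only, none or still open, it means among the compounds named here.

Measured in a functional assay on T29Kt1 cells (Homo sapiens) for cytotoxicity, read by sulforhodamine B assay, with a stated time of 3 days; on this read-out higher numbers stand for weaker inhibition and lower numbers for stronger inhibition:
- Compound 1 `O=Cc1cn(Cc2cccc(Br)c2)c2ccccc12`: 1580 nM
- Compound 2 `O=Cc1cn(Cc2cccc(C(F)(F)F)c2)c2ccccc12`: 1780 nM

The two measured values lie within the scatter of each other, so compound 2 stands level with compound 1. Going by the values given here, the only measured step is a 1.1-fold higher number from compound 1 to compound 2 (0.05 log units; within the scatter). Compound 3 `OCc1cn(Cc2cccc(C(F)(F)F)c2)c2ccccc12` has hydroxymethyl in place of formyl on an aromatic carbon. The measured step is a different change, trifluoromethyl in place of bromo, and so gives no size for this one. No step beyond the scatter is therefore expected in this assay, and the estimate rests on compound 2 at 1780 nM, with wide uncertainty. The expected step is a 1.1-fold higher number from compound 2 to compound 3 (0.05 log units; within the scatter). For compound 3 the estimated value is 2000 nM, with an expected range of 500 nM to 8000 nM.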

Compound 3, half-maximal inhibitory concentration: 560 nM
For compound 3 the middle estimate is 3.6-fold (0.55 log units) above the measured one; the measured number falls inside the stated range.
By their numbers in this assay, from the lowest: compound 3; then compounds 1 and 2 (each within the scatter of the next).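

In this assay, hydroxymethyl in place of formyl gives a 3.2-fold lower number from compound 2 to compound 3 (0.50 log units; beyond the scatter), so this position on the five-membered aromatic ring responds to a change beyond the scatter, which the earlier swap of bromo for trifluoromethyl did not show. The entering group carries a hydrogen-bond donor and formyl carries none, but no measurement connects that difference to the step, and nothing available explains it.

Going by these compounds, whether a carboxylic acid, an amine or a longer chain at this position would move the number further stays open. So does whether the same change on compound 1 gives a step of similar size.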